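A few compounds are considered here, and "the series" means these few. Any claim that something is new, unique, unknown or untested is made for them only; others in the source may bear on it.

Series notes. Going by the values given here, compound 1 `NNC(=O)CCc1ccncc1-c1ccc2ccccc2c1` gives 7.7 nM in an assay on a protein complex for inhibition of CDK8/Cyclin C (Homo sapiens), with a stated time of 1 h (a lower number here means a stronger inhibitor, a higher number a weaker inhibitor), and stands lowest of the two numbers measured so far; its nearest neighbour is compound 2 `O=C(CCc1ccncc1-c1ccc2ccccc2c1)N1CCOCC1`, which in this assay gives 45.5 nM, the step between them being a 5.9-fold higher number from compound 1 to compound 2 (0.77 log units; beyond the scatter), morpholin-4-yl in place of aminoamino on a carbonyl carbon. Compound 3 `NC(=O)/C=C/c1ccncc1-c1ccc2ccccc2c1` is not yet measured. It differs from compound 1 as follows: 2-carbamoylethenyl in place of 2-(aminocarbamoyl)ethyl on an aromatic carbon. Among the compounds with values here, no measured step makes this same change; the only step in hand, from compound 1 to compound 2, alters the group on the carbonyl carbon and shows that a change at that end of the chain can raise the number in this assay by a modest amount. Compound 3 likewise alters that end of the chain, giving up one hydrogen-bond donor and one acceptor, and gains a second double bond outside aromatic rings. A modest rise is therefore expected, a 3.2-fold higher number from compound 1 to compound 3 (0.51 log units; beyond the scatter). Compound 3 is estimated at 25 nM, with a range of 8 nM to 80 nM.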

Compound 3, half-maximal inhibitory concentration: 10.5 nM
Beside the measured number, compound 3's estimate is 2.4-fold (0.38 log units) above it, and the stated range covers the measured number.
By their numbers in this assay, from the lowest: compounds 1 and 3 (each within the scatter of the next); then compound 2.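

Replacing 2-(aminocarbamoyl)ethyl with 2-carbamoylethenyl on this aromatic carbon gives a 1.4-fold higher number from compound 1 to compound 3 (0.13 log units; within the scatter) in this assay, so a change at the end of this chain need not carry a cost like that of a 5.9-fold higher number from compound 1 to compound 2 (0.77 log units; beyond the scatter). The number stays within the scatter even though the entering group has 1 hydrogen-bond donor and 1 hydrogen-bond acceptor against 2 of each in the leaving group, and 2 double bonds outside aromatic rings against 1. No available evidence bears on this result.

The change in compound 3 combines the new chain double bond with the loss of the amino nitrogen on the amide, and the saturated 2-carbamoylethyl group would be needed to separate these two features. Going by these compounds, how a carboxylic acid or a longer chain would behave at this position remains open.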